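Working notes: butyl to pyrrolidin-1-yl on compound 3

This account rests on a few compounds, and the source may have more. Where it says the series, first, only, none or still open, it means among the compounds named here.

Measured compounds in an ADME assay on THP-1 cells (Homo sapiens) for cytotoxicity, read by resazurin assay, with a stated time of 72 h; a higher number here means that more compound is tolerated, a lower number that less compound is tolerated:
- compound 1 `CC(C)(C)c1ccc(C(=O)/C=C/c2ccc([N+](=O)[O-])o2)cc1`: the result is a limit, > 50000 nM
- compound 2 `O=C(/C=C/c1ccc([N+](=O)[O-])s1)c1ccc(-n2ccnc2)cc1`: 23400 nM
- compound 3 `CCCCc1ccc(C(=O)/C=C/c2ccc([N+](=O)[O-])o2)cc1`: 48700 nM

Compound 3 holds the highest of the two numbers in this assay; compound 2 gives 23400 nM, a gap beyond the scatter. For compound 1 only a limit is known, > 50000 nM. For the measured compounds named here, the single measured step at this position, an at least 1.0-fold lower number from compound 1 to compound 3 (0.01 log units; that floor lies within the scatter), stays within the scatter, with the note that (the limit of > 50000 nM in this assay, at which 1 of the 3 values shown sits).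

Compound 4 `O=C(/C=C/c1ccc([N+](=O)[O-])o1)c1ccc(N2CCCC2)cc1` differs from compound 3 by pyrrolidin-1-yl in place of butyl on an aromatic carbon. Going by the values given here, no measured step exchanges a chain for a ring amine here; the only related step, an at least 1.0-fold lower number from compound 1 to compound 3 (0.01 log units; that floor lies within the scatter), gives no direction. The estimate for compound 4 is therefore a step of a 1.4-fold lower number from compound 3 to compound 4 (0.14 log units; within the scatter), within the scatter, and compound 4 is expected at 35000 nM, between 12000 nM and 100000 nM.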

Compound 4, half-maximal cytotoxic concentration: > 50000 nM
Compound 4: only a limit was reported (the forecaster's own chance of this, stated with the estimate: 25%); at least 1.4-fold (0.15 log units) between middle value and limit.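

In this assay, pyrrolidin-1-yl in place of butyl on the aromatic carbon gives an at least 1.0-fold higher number from compound 3 to compound 4 (0.01 log units; that floor lies within the scatter). For the compounds shown here, this is the first measured exchange of a chain for a ring amine at this position, and it shows no lower number, although the true size of the step remains unknown. The result for compound 4 is a limit, and the step from compound 1 to compound 4 cannot be read, because both compounds carry one: the limit of > 50000 nM in this assay, at which 2 of the 4 values shown sit.

Still open, as far as these compounds go, is whether an open-chain amine, a carboxylic acid or a longer chain at this position would lower the number.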